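A Fluorine Added to a Chloropyridine Ether

The source may hold more compounds than are shown below. What is called first, only, known or untested is meant among the compounds shown, and "the series" means these compounds.

Of the compounds shown here, three sharing one core have been measured in a physicochemical assay for lipophilicity, read by LC-MS, in phosphate buffer, measured as octanol-water partition, with a stated time of 30 min, at pH 7.4, tested at 200 mM; a lower number here means a more polar compound, a higher number a more lipophilic compound. Compound 1 `Cc1ccc(Oc2ccc3nc(COc4cccc(C(=O)O)c4)n(C)c3n2)c(C)c1` gives 2.3, and compound 2 `Cn1c(COc2cccc(C(=O)O)c2)nc2cnc(Oc3ccc4c(c3)CCC4)cc21` gives 1.6. Compound 3 `Cn1c(COc2cccc(C(=O)O)c2)nc2ccc(Oc3ccc(Cl)cn3)cc21` gives 1.2, the lowest of the three numbers: compound 2 sits nearer to it and compound 1 further away, and both gaps lie beyond the usual scatter. Compound 4 `Cn1c(COc2cccc(C(=O)O)c2)nc2ccc(Oc3ncc(Cl)cc3F)cc21` has not yet been measured in this assay. It differs from compound 3 in a single place: fluoro in place of hydrogen on an aromatic carbon. Among the measured compounds shown here, no measured pair shows this change directly, so the size of the step rests on expectation alone. A small rise in this assay is expected, close to the edge of the scatter, amounting to a number 0.20 log units higher from compound 3 to compound 4 (within the scatter). Compound 4 is accordingly estimated at 1.4, within a range from 1.1 to 1.7.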

Compound 4, distribution coefficient: 1.3
Compound 4: the middle estimate sits 0.10 log units above what was measured, and the stated range covers the measured number.
By their numbers in this assay, from the lowest: compounds 3, 4 and 2 (each within the scatter of the next, the first and the last beyond it); then compound 1.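

In this assay, fluoro in place of hydrogen, ortho to a large group and two atoms from the ring nitrogen, gives a number 0.10 log units higher from compound 3 to compound 4 (within the scatter). Among the compounds shown here, this is the first pair to isolate one change, and the step from 5-chloropyridin-2-yl to 5-chloro-3-fluoropyridin-2-yl cannot be told apart from repeat-measurement variation. No available evidence bears on why the step has this size. As far as these compounds go, whether an amine or a nitrile at this position would give a step beyond the scatter remains open, as does whether fluoro elsewhere on this ring would.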